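Adding 4-methoxyphenyl to the ring nitrogen of compound 1

This account rests on a few compounds, and the source may have more. Where it says the series, first, only, none or still open, it means among the compounds named here.

Compound 1 `COc1ncc(-c2ccc3c(c2)NC(=O)CO3)cc1NS(=O)(=O)c1ccc(F)cc1` is the starting point for this step. Within the data shown here, in a functional assay on MCF7 cells (Homo sapiens) for antiproliferative activity, read by MTT assay, with a stated time of 72 h (on this read-out lower numbers stand for stronger inhibition and higher numbers for weaker inhibition), compound 1 gives 32300 nM, the only true number in the set so far. Compound 2 `COc1cccc(N2C(=O)COc3ccc(-c4ccc(O)cc4)cc32)c1` gives > 40000 nM, which is a limit and not a number. Compound 3 `O=C1COc2ccc(-c3cnc4ccccc4c3)cc2N1C1CCCCC1` gives > 40000 nM, which is also a limit and not a number.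

The step to compound 4 `COc1ccc(N2C(=O)COc3ccc(-c4cnc(OC)c(NS(=O)(=O)c5ccc(F)cc5)c4)cc32)cc1` is 4-methoxyphenyl in place of hydrogen on an amide-type nitrogen in a ring, with 4-methoxyphenyl in place of hydrogen on an amide-type nitrogen in a ring. Compounds 2 and 3 also carry a ring on that nitrogen, but both differ from compound 4 elsewhere as well. Among the measured compounds shown here, neither therefore isolates this change, and no measured pair in the set does.

The expectation rests mainly on compound 1 at 32300 nM, and it is a weak one: a modest gain in potency, with a real chance of no change beyond the scatter. The expected size of the move is a 2.7-fold lower number from compound 1 to compound 4 (0.43 log units; beyond the scatter). For compound 4 the estimated half-maximal inhibitory concentration in this assay is 12000 nM, with an expected range of 2500 nM to 40000 nM.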

Compound 4, half-maximal inhibitory concentration: 8260 nM
Compound 4: middle estimate off by 1.5-fold (0.16 log units), on the high side, and the stated range covers the measured number.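

In this assay, placing 4-methoxyphenyl on the amide-type nitrogen in place of the amide hydrogen gives a 3.9-fold lower number from compound 1 to compound 4 (0.59 log units; beyond the scatter), so this position accepts an added aromatic ring with a modest gain rather than a loss. Among these compounds, this is the first comparison that isolates the nitrogen substituent, as compounds 2 and 3 also carry a ring there but differ from compound 4 elsewhere as well. The step is modest, and compound 4 remains the only substituted compound here with a true number rather than a limit, so the wider effect of substitution at this nitrogen cannot be read from the set: the limit of > 40000 nM in this assay, at which 2 of the 4 values shown sit.

From the compounds shown here alone, with only hydrogen and 4-methoxyphenyl comparable at this nitrogen, it remains open whether the gain needs an aromatic ring at all, or whether a methyl group, a benzyl group or a dimethylaminoethyl chain would give a similar, larger or smaller step. Whether the same step holds alongside the other parts of compound 2 and compound 3 also stays open, as neither has a partner among the compounds shown that differs in one place.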